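Amine substituent swap on a shared diaryl ether core

A few compounds are considered here, and "the series" means these few. Any claim that something is new, unique, unknown or untested is made for them only; others in the source may bear on it.

Among the measured compounds shown here, compound 2 `COc1ccc(CCCNCc2c(OC)cc(Oc3cccc(Nc4ccccc4)c3)cc2OC)cc1` gives 3320 nM in a functional assay on HT-29 cells (Homo sapiens) for inhibition, read by MTT assay, with a stated time of 72 h (on this read-out higher numbers stand for weaker inhibition and lower numbers for stronger inhibition), the highest of the two numbers known, with compound 1 `COc1cc(Oc2cccc(Nc3ccccc3)c2)cc(OC)c1CNCc1ccc(F)cc1` nearest at 2750 nM, a difference that falls within the scatter. For the measured compounds named here, the one measured step, a 1.2-fold higher number from compound 1 to compound 2 (0.08 log units; within the scatter), exchanged one substituent on the amine nitrogen for another and left the number essentially where it was. Compound 3 `CCN1CCN(Cc2c(OC)cc(Oc3cccc(Nc4ccccc4)c3)cc2OC)CC1` goes further: 4-ethylpiperazin-1-yl in place of (3-(4-methoxyphenyl)propyl)amino on a saturated chain carbon bound to an aromatic carbon. Going by the values given here, no measured pair shows this kind of change, so the only guide is the step from compound 1 to compound 2, which suggests that the part of the molecule bound to the saturated chain carbon tolerates alteration without a shift beyond the scatter. On that basis the step from compound 2 to compound 3 in this assay is expected to be small, a 1.1-fold lower number from compound 2 to compound 3 (0.04 log units; within the scatter), with no clear direction. Compound 3 is therefore estimated at 3000 nM in this assay, within a range from 1100 nM to 8500 nM.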

Compound 3, half-maximal inhibitory concentration: > 20000 nM
Compound 3 was reported as a limit (the forecaster's own chance of this, stated with the estimate: 5%); middle value at least 6.6-fold (0.82 log units) from the limit.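

Compound 3 is reported only as a limit: the limit of > 20000 nM in this assay, at which 1 of the 3 values shown sits. In this assay the change to 4-ethylpiperazin-1-yl gives an at least 6.0-fold higher number from compound 2 to compound 3 (0.77 log units; beyond the scatter) and an at least 7.2-fold higher number from compound 1 to compound 3 (0.86 log units; beyond the scatter) and so shows that this place, on a saturated chain carbon bound to an aromatic carbon, does not tolerate every substituent, which the step between compound 1 and compound 2 could not show. The two substituents that stay within the scatter of each other, (4-fluorobenzyl)amino and (3-(4-methoxyphenyl)propyl)amino, both carry an aromatic ring and an amine hydrogen, and 4-ethylpiperazin-1-yl carries neither.

The compounds shown leave open which of these differences matters, or whether the piperazine ring itself does. A 4-benzylpiperazin-1-yl group or an open-chain amine such as diethylamino at this place would help to separate them.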